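Methylpiperazine for Methoxy, Repeated on a Second Core

The source may hold more compounds than are shown below. What is called first, only, known or untested is meant among the compounds shown, and "the series" means these compounds.

Compound 1 `COc1ccc(-c2cc3[nH]nc(N)c3c(=O)[nH]2)cc1` and compound 2 `CN1CCN(c2ccc(-c3cc4[nH]nc(N)c4c(=O)[nH]3)cc2)CC1` share one core and differ in a single place: 4-methylpiperazin-1-yl in place of methoxy on an aromatic carbon. In an assay on isolated protein for inhibition of serine/threonine-protein kinase D2 (Homo sapiens), read by mobility shift assay, tested at 30 uM (a lower number here means less inhibition, a higher number more inhibition at the concentration tested (going by the name of the read-out)), compound 1 gives 28%, while compound 2 gives 15%, so this exchange produced a number 13 percentage points lower from compound 1 to compound 2 (beyond the scatter).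

Compound 3 `COc1ccc(-c2cc3nn(-c4ccccc4)c(N)c3c(=O)[nH]2)cc1` is built on a different core; the difference between the two cores is not broken down here. In this assay compound 3 gives 28%, level with compound 1 at the digits shown and apart from compound 2.

Compound 4 `CN1CCN(c2ccc(-c3cc4nn(-c5ccccc5)c(N)c4c(=O)[nH]3)cc2)CC1` stands to compound 3 as compound 2 stands to compound 1: 4-methylpiperazin-1-yl in place of methoxy on an aromatic carbon. The place is described in the same words in both pairs, so this is the same change made a second time, the only two occurrences among the compounds shown.

Within the data shown here, with only one earlier example to go on, compound 4 is expected to show a number 13 percentage points lower from compound 3 to compound 4 (beyond the scatter) in this assay, because the earlier pair gave a number 13 percentage points lower from compound 1 to compound 2 (beyond the scatter). Compound 4 is therefore estimated at 15%, with a likely range from 3% to 27%.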

Compound 4, a percentage reported as inhibition, at one concentration (the size of the read-out at that concentration, not a potency): 15%
Compound 4: the middle estimate sits on the measured number at the digits printed; low and high end bracket the measured number.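

In this assay, placing 4-methylpiperazin-1-yl where methoxy stood on the second core gave a number 13 percentage points lower from compound 3 to compound 4 (beyond the scatter), so the change carried over to this core. Set beside the earlier pair, the two steps do not differ: the same change on two cores in this assay, a number 13 percentage points lower (beyond the scatter) from compound 1 to compound 2 and a number 13 percentage points lower (beyond the scatter) from compound 3 to compound 4, 0 percentage points apart, within the scatter of two such steps. This shows that, in these two pairs, the size of the step did not depend on which of the two cores carried the change, but two pairs cannot establish a rule for the series, and these readings, taken at a single concentration, are not potencies and give no reason for the drop.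

The compounds shown leave open whether a morpholine, a primary amine or a carboxylic acid on the same aromatic carbon would give a similar step, or whether the step depends on the methylpiperazine itself. They also leave open whether the exchange of methoxy for 4-methylpiperazin-1-yl would give the same step on any core beyond these two.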